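Allylsulfanyl analogue in the cytotoxicity series

A few compounds are considered here, and "the series" means these few. Any claim that something is new, unique, unknown or untested is made for them only; others in the source may bear on it.

Measured compounds:
compound 1 `Cc1cc(N2CC[C@@H](C)[C@@H](N(C)c3ncnc4[nH]ccc34)C2)n2nc(SCC3CCCCC3)nc2n1`: 98200 nM
compound 2 `Cc1cc(N2CC[C@@H](C)[C@@H](N(C)c3ncnc4[nH]ccc34)C2)n2nc(SCC3CC3)nc2n1`: 27900 nM
compound 3 `Cc1cc(N2CC[C@@H](C)[C@@H](N(C)c3ncnc4[nH]ccc34)C2)n2nc(SCc3cc(Cl)ccc3Cl)nc2n1`: 87500 nM

In a toxicity assay on GES1 cells (Homo sapiens) for inhibition, read by MTT assay, with a stated time of 72 h (on this read-out lower numbers stand for stronger inhibition and higher numbers for weaker inhibition), compound 3 gives the second highest number of the three. Its nearest neighbour is compound 1, and the two lie within the scatter of each other, as a 1.1-fold lower number from compound 1 to compound 3 (0.05 log units; within the scatter) shows. The step to compound 2 is larger: a 3.1-fold higher number from compound 2 to compound 3 (0.50 log units; beyond the scatter), beyond the scatter. Compound 4 `C=CCSc1nc2nc(C)cc(N3CC[C@@H](C)[C@@H](N(C)c4ncnc5[nH]ccc45)C3)n2n1` differs from compound 3 in one place: vinyl in place of 2,5-dichlorophenyl on a saturated chain carbon bound to a sulfur.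

Going by the values given here, the steps that bear on this change are those where the group on the saturated chain carbon bound to a sulfur shrinks. The move from cyclohexyl to cyclopropyl gave a 3.5-fold lower number from compound 1 to compound 2 (0.55 log units; beyond the scatter), and the move from cyclopropyl to 2,5-dichlorophenyl gave a 3.1-fold higher number from compound 2 to compound 3 (0.50 log units; beyond the scatter). Vinyl is a small group like cyclopropyl, so a lower number in this assay is expected for compound 4, of modest size, estimated as a 2.5-fold lower number from compound 3 to compound 4 (0.40 log units; beyond the scatter). The estimate for compound 4 in this assay is 35000 nM, in the range 12000 nM to 100000 nM.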

Compound 4, half-maximal inhibitory concentration: > 100000 nM
Compound 4: no number, only a limit; the forecaster's own chance of this, stated with the estimate: 15%; middle value at least 2.8-fold (0.45 log units) away from the limit.
By their numbers in this assay, from the lowest: compound 2; then compounds 3 and 1 (each within the scatter of the next). At a limit, above all of these: compound 4.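

Compound 4 carries no number in this assay, only a limit: the limit of > 100000 nM in this assay, at which 1 of the 4 values shown sits.

Going by these compounds alone, the one readable new step, vinyl in place of cyclopropyl on a saturated chain carbon bound to a sulfur, gives an at least 3.5-fold higher number from compound 2 to compound 4 (0.55 log units; beyond the scatter) and so two compact groups at this place do not read alike, and a lower number in this set does not simply follow a smaller group. Within the data shown here, compound 2 remains the only compound set apart by a lower number, while the steps of an at least 1.1-fold higher number from compound 3 to compound 4 (0.05 log units; that floor lies within the scatter) and an at least 1.0-fold higher number from compound 1 to compound 4 (0.00 log units; that floor lies within the scatter) cannot be read, as their floors lie within the scatter.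

On these data alone, how far compound 4 actually lies from compounds 1 and 3 stays open. Also open, as far as these compounds go, is whether a longer chain, an amine or a carboxylic acid at this place would read like compound 2 or like compound 4.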